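The source may hold more compounds than are shown below. What is called first, only, known or untested is meant among the compounds shown, and "the series" means these compounds.

Of the compounds shown here, three have so far been measured in an assay on isolated protein for inhibition of aldehyde dehydrogenase 1A1 (Homo sapiens), read by spectrophotometry, tested at 10 uM; a higher number here means more inhibition at the concentration tested (going by the name of the read-out), a lower number less inhibition. Compound 1 `Cc1cccc(Cn2c(OC3CCN(C(=O)c4ccco4)CC3)nc3ccccc32)c1` gives 68.3%, compound 2 `O=C(C1CC1)N1CCN(Cc2nc3ccccc3n2Cc2ccccc2C(F)(F)F)CC1` gives 56.3%, and compound 3 `Cc1cccc(Cn2c(CN3CCN(C(=O)C4CCCCC4)CC3)nc3ccccc32)c1` gives 31.9%. On these numbers compound 3 stands lowest of the three: the nearest to it is compound 2, whose value lies higher by a margin beyond the usual scatter, and compound 1 lies higher still, also beyond the scatter. Compound 4 `CCCC(=O)N1CCN(Cc2nc3ccccc3n2Cc2cccc(C)c2)CC1` has not yet been measured in this assay. It differs from compound 3 in a single place: propyl in place of cyclohexyl on a carbonyl carbon. For the measured compounds named here, no measured pair shows this same exchange, so there is no measured step to lean on, and compound 2 differs from compound 3 in more than one place, so its value cannot be assigned to any one change. On the numbers available, one expects no step beyond the scatter from compound 3 to compound 4, perhaps a slight fall, and the step that the estimate means is a number 3.9 percentage points lower from compound 3 to compound 4 (within the scatter). Compound 4 is therefore expected to give about 28% in this assay, with a plausible range from 10% to 50%.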

Compound 4, a percentage reported as inhibition, at one concentration (the size of the read-out at that concentration, not a potency): 79.1%
For compound 4 the middle estimate is 51.1 percentage points below the measured one; measured number above the stated range.
By their numbers in this assay, from the lowest: compound 3; then compound 2; then compound 1; then compound 4.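

In this assay, the exchange of cyclohexyl for propyl on a carbonyl carbon whose other neighbour is an amide-type nitrogen in a ring gives a large change, a number 47.2 percentage points higher from compound 3 to compound 4 (beyond the scatter). The earlier compounds shown here differ from one another in more than one place, so they could not tie any difference to this position; this pair shows that the group on this carbonyl carbon alone can move the read-out well beyond the scatter, and that here the open propyl chain is the better of the two groups. No measurement at hand bears on why the read-out responds so strongly to this change.

The exchange removes the ring and shortens the carbon count together, so the compounds shown leave open which of the two matters: an open hexyl chain, which keeps the carbon count of cyclohexyl without the ring, or a branched isopropyl group, would separate them. Also open, going by these compounds, is whether the same exchange would carry over to a compound with a different group elsewhere on the shared core, such as the trifluoromethyl-bearing benzyl group of compound 2.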